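The source may hold more compounds than are shown below. What is called first, only, known or untested is meant among the compounds shown, and "the series" means these compounds.

Working notes on the sulfonamide acid series, followed in a functional assay (aorta) for inhibition, with Rattus norvegicus as the target; a higher number here means a weaker inhibitor, a lower number a stronger inhibitor.

Compound 1 `O=C(O)CCCCNS(=O)(=O)c1ccccc1` gives > 140000 nM, which is a limit of the assay and not a number. Compound 2 `O=C(O)CCCCCNS(=O)(=O)c1ccccc1` gives > 140000 nM in this assay, again a limit rather than a number. Going by the values given here, compound 3 `O=C(O)CCCCCCCNS(=O)(=O)c1ccccc1` gives 2800 nM in this assay and so holds the only measured number in the set. Compounds 1 and 2 sit at a limit (the limit of > 140000 nM in this assay, at which 2 of the 3 values shown sit). The step that the two limits leave unreadable from compound 1 to compound 2 stays unreadable. The steps of an at least 50-fold lower number from compound 1 to compound 3 (1.69 log units; beyond the scatter) and an at least 50-fold lower number from compound 2 to compound 3 (1.69 log units; beyond the scatter) are both large and both run toward lower numbers as the chain grows.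

Compound 4 `O=C(O)CCCCCCCCNS(=O)(=O)c1ccccc1` is not yet measured. Against compound 3 the change is carboxymethyl in place of carboxy on a saturated chain carbon, seven bonds along the chain from a sulfonamide nitrogen. The two readable steps, each a chain lengthening ending at compound 3, bear on it and each was at least large; no compound shown runs against the trend, though all lie in one direction and compound 3 is the only numeric anchor. For compound 4 a further but modest lowering is therefore expected, estimated as a 2.3-fold lower number from compound 3 to compound 4 (0.37 log units; beyond the scatter). A step as large as the measured ones cannot be assumed from a single number. Compound 4 is estimated at 1200 nM in this assay, within a range from 300 nM to 5000 nM.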

Compound 4, half-maximal inhibitory concentration: 1600 nM
Beside the measured number, compound 4's estimate is 1.3-fold (0.12 log units) below it; the range from low to high includes it.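

Carboxymethyl in place of carboxy, on a saturated chain carbon seven bonds along the chain from a sulfonamide nitrogen, gives in this assay a 1.8-fold lower number from compound 3 to compound 4 (0.24 log units; within the scatter), so this lengthening does not separate compound 3 and compound 4, and the large steps seen earlier do not carry over to this position. Large steps remain only where the series starts from a limit of the assay, an at least 87-fold lower number from compound 2 to compound 4 (1.94 log units; beyond the scatter) and an at least 87-fold lower number from compound 1 to compound 4 (1.94 log units; beyond the scatter), which places the readable gain in the chain lengths that end at compound 3 and makes the pair of compound 3 and compound 4 the exception to any steady lowering with length. 3-Carboxypropyl in place of carboxy can now be read at two places in the chain, though neither size is closed: the same change on two cores in this assay, an at least 50-fold lower number (1.69 log units; beyond the scatter) from compound 1 to compound 3 and an at least 87-fold lower number (1.94 log units; beyond the scatter) from compound 2 to compound 4; the limit leaves it open whether they differ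

Going by these compounds, compounds 1 and 2 give no number from which the start of the activity could be fixed, and where along the chain it begins stays open: the limit of > 140000 nM in this assay, at which 2 of the 4 values shown sit. Whether a longer chain than that of compound 4 holds this level or departs from it, and whether a primary amide can stand in place of the carboxylic acid at the chain end, also remain open.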